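Chloro for methoxy on the pyridine of compound 2

A few compounds are considered here, and "the series" means these few. Any claim that something is new, unique, unknown or untested is made for them only; others in the source may bear on it.

Measured values in an ADME assay on LLC-PK1 cells (Sus scrofa) for permeability, read by LC-MS, with a stated time of 2 h, tested at 5 uM; a lower number here means that the compound crosses the layer more slowly, a higher number that the compound crosses the layer faster:
- compound 1 `CC#Cc1cncc(-c2ccc3c(c2)[C@@]2(COC(N)=N2)c2cc(Cl)ncc2O3)c1`: 22 nm/s
- compound 2 `COc1cc2c(cn1)Oc1ccc(NC(=O)c3ccc(Cl)cn3)cc1[C@@]21COC(N)=N1`: 25 nm/s
- compound 3 `NC1=N[C@@]2(CO1)c1cc(-c3cncc(C#CCO)c3)ccc1Oc1cnc(C3=CCOCC3)cc12`: 15 nm/s

Of the compounds shown here, three share the core and have been measured in this assay. Compound 2 gives the largest of the three numbers, but its gap to compound 1 is the smallest and even its gap to compound 3 stays within the usual scatter, so the three values cannot be put into any order; they read as one cluster of slow-moving compounds.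

Compound 4 `NC1=N[C@@]2(CO1)c1cc(NC(=O)c3ccc(Cl)cn3)ccc1Oc1cnc(Cl)cc12` is not yet measured. Among the compounds with values here, its only difference from compound 2 is chloro in place of methoxy on an aromatic carbon.

Within the data shown here, no step between two measured compounds in this assay is available for a change of this kind, so the expectation rests on the cluster alone. Given that compound 2 gives 25 nm/s and that compound 1 and compound 3 sit close by, the step from compound 2 to compound 4 is expected to be small, at most a modest rise, and most likely none beyond the scatter, with an expected 1.3-fold higher number from compound 2 to compound 4 (0.11 log units; within the scatter). For compound 4 the estimated value in this assay is 32 nm/s, with a range from 14 nm/s to 70 nm/s.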

Compound 4, apparent permeability: 28 nm/s
Beside the measured number, compound 4's estimate is 1.1-fold (0.06 log units) above it; measured number inside the range.
By their numbers in this assay, from the lowest: compounds 3, 1, 2 and 4 (each within the scatter of the next).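

In this assay, within the data shown here, chloro in place of methoxy on this aromatic carbon, next to the ring nitrogen, gives a 1.1-fold higher number from compound 2 to compound 4 (0.05 log units; within the scatter) and is the first one-place step read at this position; the two compounds cannot be told apart, so exchanging these two groups here leaves no readable mark on the number. With chloro held at this position, ((5-chloropyridin-2-yl)carbonyl)amino in place of 5-(prop-1-yn-1-yl)pyridin-3-yl gives a 1.3-fold higher number from compound 1 to compound 4 (0.10 log units; within the scatter) and likewise stays within the scatter, so neither one-place step separates these compounds in this read-out. No measurement on hand speaks to the reason for either result.

Among these compounds, whether the methoxy-to-chloro step reads the same with 5-(prop-1-yn-1-yl)pyridin-3-yl in the other place remains open, as the only step at this position carries the ((5-chloropyridin-2-yl)carbonyl)amino group. Also open, as far as these compounds go, is whether an amine, a carboxylic acid or a longer alkoxy chain such as propoxy at this position would give a step beyond the scatter, since the two groups compared here mark out only a narrow part of what the position could hold.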